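Quinoline chalcone series: aminothiophene ketone, antiproliferative estimate

The compounds below may be only part of what the source reports. "The series", "measured", "known", "first", "only" and "open" are said of these compounds alone.

Measured so far:
compound 1, `COc1ccc(-c2cc3ccccc3nc2/C=C/C(=O)c2c(OC)cccc2OC)cc1`, 3830 nM
compound 2, `COc1ccc(-c2cc3ccccc3nc2/C=C/C(=O)c2cccs2)cc1`, 800 nM

Both were run in a functional assay on SK-BR-3 cells (Homo sapiens) for antiproliferative activity, read by XTT assay, with a stated time of 72 h; on this read-out higher numbers stand for weaker inhibition and lower numbers for stronger inhibition. Among the measured compounds shown here, the one measured step, a 4.8-fold lower number from compound 1 to compound 2 (0.68 log units; beyond the scatter), changes the aryl ring on the carbonyl. Compound 2 therefore holds the lowest number of the two, with compound 1 standing at a higher number, beyond the scatter.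

The next compound, compound 3, `COc1ccc(-c2cc3ccccc3nc2/C=C/C(=O)c2sccc2N)cc1`, keeps the ketone-linked ring of compound 2 and adds one atom: amino in place of hydrogen on an aromatic carbon, i.e. thiophen-2-yl becomes 3-aminothiophen-2-yl. For the measured compounds named here, no measured step touches a substituent on this ring; the step from compound 1 to compound 2 swaps the whole aryl and so gives no guide to the effect of an amino on it. With nothing to anchor a direction, the expectation for compound 3 is a step of about a 1.1-fold lower number from compound 2 to compound 3 (0.06 log units; within the scatter), i.e. none beyond the scatter. Compound 3 is estimated at 700 nM in this assay, within 250 nM to 2500 nM.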

Compound 3, half-maximal inhibitory concentration: > 10000 nM
Compound 3 was reported as a limit (the forecaster's own chance of this, stated with the estimate: 5%); middle value at least 14-fold (1.15 log units) away from the limit.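

In this assay compound 3 stands as a limit: the limit of > 10000 nM in this assay, at which 1 of the 3 values shown sits. This carbon of the thiophen-2-yl ketone, next to the ring atom that bears a large group and two ring bonds from the ring sulfur, does not tolerate every small change, as amino in place of hydrogen gives an at least 12-fold higher number from compound 2 to compound 3 (1.09 log units; beyond the scatter). The earlier advantage of thiophen-2-yl over 2,6-dimethoxyphenyl does not carry over to the amino-bearing ring, with 3-aminothiophen-2-yl giving an at least 2.6-fold higher number from compound 1 to compound 3 (0.41 log units; beyond the scatter).

These compounds give no cause for the loss, and a single substituent cannot show whether it follows from amino itself or from any group at this carbon. Open too, going by these compounds, is how a methyl, a hydroxyl or an acetamide would behave on the same carbon.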